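A few compounds are considered here, and "the series" means these few. Any claim that something is new, unique, unknown or untested is made for them only; others in the source may bear on it.

Compound 1 `c1ccc(-c2n[nH]cc2N2CCNCC2)cc1`: > 10000 nM
Compound 2 `Fc1ccccc1-c1n[nH]cc1N1CCNCC1`: > 10000 nM

In an assay on isolated protein for binding affinity to 5-hydroxytryptamine receptor 1D (Homo sapiens) (a higher number here means a weaker inhibitor, a lower number a stronger inhibitor), compound 1 gives > 10000 nM, which is a limit of the assay and not a number. Compound 2 gives > 10000 nM in this assay, again a limit. Among the measured compounds shown here, compound 1 therefore stands at the boundary of what the assay reports, as does the one other value shown (the limit of > 10000 nM in this assay, at which 2 of the 2 values shown sit). Compound 3 `Fc1cccc(-c2n[nH]cc2N2CCNCC2)c1` differs from compound 1 by fluoro in place of hydrogen on an aromatic carbon. For the measured compounds named here, the single measured step, a step that the two limits leave unreadable from compound 1 to compound 2, is the only comparison that bears on this change, and its size cannot be read because both ends are limits. Nothing in these two values gives ground to expect a step in this assay in either direction beyond the scatter. For compound 3 the expected value is 15000 nM, with a range from 3000 nM to 80000 nM, and most probably it would be reported again only as a limit. The step this estimate means, a step that the limit leaves unreadable from compound 1 to compound 3, is expected to be negligible.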

Compound 3, inhibition constant: 911 nM
Estimate against measurement, compound 3: 16-fold (1.22 log units) above; measured number below the stated range.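

In this assay, fluoro in place of hydrogen on an aromatic carbon, meta to a large group, gives an at least 10-fold lower number from compound 1 to compound 3 (1.04 log units; beyond the scatter), so this small change at this position can produce a measurable number. Compound 2 carries the same fluoro on a different carbon of that ring and gives > 10000 nM, which is a limit of the assay and not a number, so the position of the fluoro matters among the compounds shown. The full size of the step stays open, because compound 1 sits at a limit of the assay: the limit of > 10000 nM in this assay, at which 2 of the 3 values shown sit.

The compounds shown leave open whether this carbon needs fluoro specifically or whether chloro, methoxy or trifluoromethyl there would serve as well. They also leave open what an amine or a hydroxyl at the same carbon would do.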